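Bromo to acetoxy on the aromatic carbon

The source may hold more compounds than are shown below. What is called first, only, known or untested is meant among the compounds shown, and "the series" means these compounds.

Measured in a functional assay (muscle tissue) with Cavia porcellus as the target (a higher number here means that more compound is needed for the effect, a lower number that less compound is needed), so far:
- Compound 1 `COC(=O)C1=C(C)N=C(C)/C(=C(\O)OC)C1c1cccc(OC)c1` gives 191 nM
- Compound 2 `COC(=O)C1=C(C)N=C(C)/C(=C(\O)OC)C1c1cccc(Br)c1` gives 1.29 nM

Compound 2 stands lowest of the two measured compounds. Compound 3 `COC(=O)C1=C(C)N=C(C)/C(=C(\O)OC)C1c1cccc(OC(C)=O)c1` differs from compound 2 through acetoxy in place of bromo on an aromatic carbon with acetoxy in place of bromo on an aromatic carbon. Among the compounds with values here, one measured step bears on this, the large 150-fold lower number from compound 1 to compound 2 (2.17 log units; beyond the scatter) for bromo in place of methoxy. Like the methoxy of compound 1 at 191 nM acetoxy is joined through oxygen, so a smaller step towards a higher number, still beyond the scatter, is expected in this assay for this change. The estimate means a 31-fold higher number from compound 2 to compound 3 (1.49 log units; beyond the scatter) as the expected step. For compound 3 the estimated value is 40 nM within an expected range of 6 nM to 250 nM in this series.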

Compound 3, half-maximal effective concentration: 6030 nM
Beside the measured number, compound 3's estimate is 150-fold (2.18 log units) below it; the whole stated range lies below it.
By their numbers in this assay, from the lowest: compound 2; then compound 1; then compound 3.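

At this aromatic carbon, the group carried there moves the number in this assay across a far wider span than the earlier pair showed, with a 4700-fold higher number from compound 2 to compound 3 (3.67 log units; beyond the scatter). Groups joined through oxygen also do not read as one class: acetyl in place of methyl on that oxygen gives a 32-fold higher number from compound 1 to compound 3 (1.50 log units; beyond the scatter). Nothing on hand accounts for either step. From the compounds shown here alone, whether a free hydroxyl, an amine or a chloro group here would sit nearer compound 2 or compound 3 remains open. So does whether the low number of compound 2 is particular to bromo.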